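Turning a ketone side chain back into an alcohol

The compounds below may be only part of what the source reports. "The series", "measured", "known", "first", "only" and "open" are said of these compounds alone.

The series shares one core with a branched aryl ether side chain, read in an assay on HL-60 cells for agonist activity at vitamin D3 receptor (Homo sapiens), read by microscopy, with a stated time of 96 h; a higher number here means that more compound is needed for the effect, a lower number that less compound is needed. Compound 1 `CC[C@@H](C)[C@H](NC(=O)c1ccc(C(CC)(CC)c2ccc(OCC(O)C(C)(C)C)c(C)c2)n1CC)C(=O)O` carries a 1-hydroxy-2,2-dimethylpropyl on that chain, and in this assay compound 1 gives 2.3 nM. Compound 2 `CCn1c(C(=O)Nc2cccc(C(F)(F)F)c2)ccc1C(CC)(CC)c1ccc(OCC(=O)C(C)(C)C)c(C)c1` instead carries a (tert-butyl)carbonyl there, together with a different amide part. For compound 2 this assay reports only a limit, > 50000 nM, so compound 2 stands at the weak end of the two values shown, at the limit of > 50000 nM in this assay, at which 1 of the 2 values shown sits.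

Compound 3 `CCn1c(C(=O)Nc2cccc(C(F)(F)F)c2)ccc1C(CC)(CC)c1ccc(OCC(O)C(C)(C)C)c(C)c1` is compound 2 with the change (1-hydroxy-2,2-dimethylpropyl in place of (tert-butyl)carbonyl on a saturated chain carbon bound to an oxygen on an aromatic ring). Within the data shown here, no step between measured compounds covers this swap alone; compound 1 and compound 2 differ in two places, so their values only show that the hydroxyl-bearing compound 1 is measurable while compound 2 is not. Compound 3 is therefore expected to move far from the limit, a step of an at least 330-fold lower number from compound 2 to compound 3 (2.52 log units; beyond the scatter) well beyond the scatter. Compound 3 is estimated at 150 nM, within 10 nM to 5000 nM.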

Compound 3, half-maximal effective concentration: > 50000 nM
Compound 3: no number, only a limit; the forecaster's own chance of this, stated with the estimate: 20%; middle value at least 330-fold (2.52 log units) from the limit.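

In this assay, compound 3 shares the 1-hydroxy-2,2-dimethylpropyl with compound 1 and differs from it in one place only, with 3-(trifluoromethyl)phenyl in place of 1-carboxy-2-methylbutyl on the amide nitrogen, and that single change is an at least 21000-fold higher number from compound 1 to compound 3 (4.33 log units; beyond the scatter). The alcohol on this chain is therefore not enough on its own for a measurable value, and the group on the amide nitrogen decides the outcome in this pair. Compound 2 and compound 3 both give only a limit of the assay, so the step between them cannot be read and the swap of (tert-butyl)carbonyl for 1-hydroxy-2,2-dimethylpropyl shows nothing measurable with this amide part: the limit of > 50000 nM in this assay, at which 2 of the 3 values shown sit.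

What the (tert-butyl)carbonyl does on the chain when 1-carboxy-2-methylbutyl stands on the amide nitrogen stays open, as the compounds shown hold no such pair. Also open, as far as these compounds go, is whether another group on that nitrogen, such as an aminoethyl group, would bring the value back within the measurable range.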